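Bromo for fluoro on the fused aromatic ring of compound 2

A few compounds are considered here, and "the series" means these few. Any claim that something is new, unique, unknown or untested is made for them only; others in the source may bear on it.

Of the compounds shown here, three that share one core have been tested in a functional assay on PC-3 cells (Homo sapiens) for inhibition, read by sulforhodamine B assay, with a stated time of 48 h; on this read-out higher numbers stand for weaker inhibition and lower numbers for stronger inhibition. Compound 1 `CCO[C@H]1C[C@@H](c2coc3ccc(F)cc3c2=O)N(c2ccccc2)O1` gives 31700 nM. Compound 2 `O=c1c([C@@H]2C[C@H](c3ccccc3)ON2c2ccccc2)coc2ccc(F)cc12` gives 49000 nM. Compound 3 `O=C1[C@H]2[C@H](ON(c3ccccc3)[C@@H]2c2coc3ccc(F)cc3c2=O)C(=O)N1c1ccccc1` reaches only the limit of this assay at > 60000 nM. Of the two compounds with a number, compound 2 sits closest to compound 1, and the step of a 1.5-fold higher number from compound 1 to compound 2 (0.19 log units; within the scatter) lies within the scatter, so the two cannot be ordered.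

Compound 4 `O=c1c([C@@H]2C[C@H](c3ccccc3)ON2c2ccccc2)coc2ccc(Br)cc12` differs from compound 2 in one place: bromo in place of fluoro on an aromatic carbon. Among the measured compounds shown here, no measured step touches that position. For the measured compounds named here, the only measured step, from compound 1 to compound 2, exchanges a group on a saturated ring carbon and was itself within the scatter; the exchange in compound 3 adds a fused ring and ends at a limit. Nothing among these values therefore argues for a change beyond the scatter when fluoro becomes bromo. Compound 4 is consequently expected to give about 45000 nM in this assay, with a plausible range from 18000 nM to 120000 nM. The estimated step of a 1.1-fold lower number from compound 2 to compound 4 (0.04 log units; within the scatter) is expected to stay within the scatter of the measurement.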

Compound 4, half-maximal inhibitory concentration: 60000 nM
Compound 4: middle estimate off by 1.3-fold (0.12 log units), on the low side; measured number inside the range.
By their numbers in this assay, from the lowest: compounds 1, 2 and 4 (each within the scatter of the next).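

In this assay, bromo in place of fluoro on the aromatic carbon gives a 1.2-fold higher number from compound 2 to compound 4 (0.09 log units; within the scatter), so compound 2 and compound 4 cannot be ordered. Among the compounds shown here, this is the first measured step at this position, on a six-membered aromatic ring of carbon only, meta to a fused ring and para to a fused ring; the earlier step concerned a saturated ring carbon, and now an exchange on the aromatic part of the shared core has also stayed within the scatter, though for this one pair of halogens and with phenyl on the saturated ring carbon. Compound 3 remains the only compound with a limit and not a number: the limit of > 60000 nM in this assay, at which 1 of the 4 values shown sits.

The compounds shown leave open whether an amine, a methoxy group or a carboxylic acid on this aromatic carbon would give a step beyond the scatter. They also leave open whether bromo in place of fluoro would give a step of similar size with ethoxy on the saturated ring carbon, as in compound 1.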